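A few compounds are considered here, and "the series" means these few. Any claim that something is new, unique, unknown or untested is made for them only; others in the source may bear on it.

Measured in a physicochemical assay for lipophilicity, read by HPLC, at pH 7.4; on this read-out higher numbers stand for higher lipophilicity and lower numbers for lower lipophilicity:
- Compound 1 `Cc1cc(Br)ccc1C(=O)Nc1ccccn1` gives 3.2
- Compound 2 `Cc1c(F)cccc1C(=O)Nc1ccccn1` gives 2.6
- Compound 3 `Cc1ccccc1C(=O)Nc1cc(C#N)ccn1` gives 2.8

Compound 3 (2.8) lies within the usual scatter of compound 2 (2.6), while compound 1 (3.2) stands higher than compound 3, beyond the scatter.

For the measured compounds named here, the next compound, compound 4 `Cc1ccccc1C(=O)Nc1cc(C#Cc2ccccc2)ccn1`, has no measurement yet. It carries 2-phenylethynyl in place of cyano on an aromatic carbon, opposite the ring nitrogen (2-phenylethynyl in place of cyano on an aromatic carbon). Going by the values given here, no two measured compounds differ in one place only, so the data offer no direct step to lean on, and the expectation rests on the structural change alone. A small nitrile gives way to a much larger group built only of carbon, so a clear rise in this assay is expected, well beyond the scatter. Starting from compound 3 (2.8), the expected rise is large (a number 1.70 log units higher from compound 3 to compound 4 (beyond the scatter)). Compound 4 is estimated at 4.5 with an expected range from 3.8 to 5.2 in this measurement.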

Compound 4, distribution coefficient: 4.7
Estimate against measurement, compound 4: 0.20 log units below; low and high end bracket the measured number.
By their numbers in this assay, from the lowest: compounds 2 and 3 (each within the scatter of the next); then compound 1; then compound 4.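

For the compounds shown here, this pair is the first in the set to differ in one place only, so the aromatic carbon opposite the ring nitrogen now has a measured step: in this assay, 2-phenylethynyl in place of cyano gives a number 1.90 log units higher from compound 3 to compound 4 (beyond the scatter). The swap changes several things at once, since the triple bond stays while a six-membered aromatic ring of carbon only comes in and the hydrogen-bond acceptor of the cyano group goes. Nothing in the data explains the size of this step.

The compounds shown leave open how much of the step belongs to the added ring and how much to the longer reach of the group, a question that a lone phenyl or a plain ethyl chain on that carbon could help to settle. They also leave open how an amine or a carboxylic acid at this place would read in this assay.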